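The compounds below may be only part of what the source reports. "The series", "measured", "known", "first", "only" and "open" are said of these compounds alone.

Measured compounds:
compound 1 `COc1ccc(-c2nc(CSc3cccc(Br)c3)nc3ccsc23)cn1`: > 50000 nM
compound 2 `O=S(=O)(Cc1nc(-c2ccnc(Cl)c2)c2sccc2n1)c1cccc(Cl)c1`: 63000 nM

In an ADME assay on cells (Homo sapiens) for cytotoxicity, read by resazurin assay, with a stated time of 5 days (a lower number here means that less compound is tolerated, a higher number that more compound is tolerated), compound 1 gives > 50000 nM, which is a limit of the assay rather than a number (the limit of > 50000 nM in this assay, at which 1 of the 2 values shown sits). Compound 2 gives 63000 nM in this assay. Compound 3 `COc1ccc(-c2nc(CSc3cccc(Cl)c3)nc3ccsc23)cn1` has not been measured; it carries chloro in place of bromo on an aromatic carbon. Going by the values given here, no measured pair shows how such a change moves this assay, so no step beyond the usual scatter is expected in this assay. Compound 3 is therefore expected to sit near the limit, estimated at 60000 nM with a range from 30000 nM to 150000 nM, an expected step that the limit leaves unreadable from compound 1 to compound 3.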

Compound 3, half-maximal cytotoxic concentration: > 10000 nM
Compound 3: a limit, no number (the forecaster's own chance of this, stated with the estimate: 70%); the middle value lies beyond the limit too.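

Going by these compounds alone, compound 1 and compound 3 each give only a limit, not a number, so no step between them can be read. On these data alone, whether chloro in place of bromo moves the tolerated concentration at all stays open.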